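Dropping one methyl from the aryl group of compound 1

This account rests on a few compounds, and the source may have more. Where it says the series, first, only, none or still open, it means among the compounds named here.

Within the data shown here, in a functional assay on A549 cells (Homo sapiens) for inhibition, read by MTT assay, with a stated time of 72 h (a higher number here means a weaker inhibitor, a lower number a stronger inhibitor), compound 1 `COc1cc2c(Oc3ccc(NC(=O)c4nn(-c5ccc(C)cc5C)cc(C)c4=O)cc3)ccnc2cc1OCCCCCCC(=O)NO` gives 1840 nM, the lowest of the three numbers so far. Compound 3 `COc1cc2c(Oc3ccc(NC(=O)c4nn(-c5ccccc5C)ccc4=O)cc3F)ccnc2cc1OCCCC(=O)NO` gives 5740 nM and compound 2 `COc1cc2c(Oc3ccc(NC(=O)c4nn(-c5ccccc5C)cc(C)c4=O)cc3)ccnc2cc1OCC(=O)NO` gives 5980 nM. Both lie beyond the scatter from compound 1. Neither differs from compound 1 in one place only, so no measured step sizes the next change directly.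

Compound 4 `COc1cc2c(Oc3ccc(NC(=O)c4nn(-c5ccc(C)cc5)cc(C)c4=O)cc3)ccnc2cc1OCCCCCCC(=O)NO` keeps the rest of compound 1 and alters a single site, with 2,4-dimethylphenyl becoming 4-methylphenyl: hydrogen in place of methyl on an aromatic carbon. This is hydrogen in place of methyl on an aromatic carbon, ortho to a large group and meta to a methyl group.

Among the measured compounds shown here, with no measured precedent for this change, the working expectation in this assay is no step beyond the scatter, and no firm direction is assumed. The expected step is small, a 1.1-fold higher number from compound 1 to compound 4 (0.06 log units; within the scatter). For compound 4 the estimated value is 2100 nM, with an expected range of 900 nM to 4800 nM.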

Compound 4, half-maximal inhibitory concentration: 160 nM
For compound 4 the middle estimate is 13-fold (1.12 log units) above the measured one, and the stated range ends above it.
By their numbers in this assay, from the lowest: compound 4; then compound 1; then compounds 3 and 2 (each within the scatter of the next).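

In this assay, among these compounds, going from 2,4-dimethylphenyl to 4-methylphenyl gives a 12-fold lower number from compound 1 to compound 4 (1.06 log units; beyond the scatter) and is the first one-place comparison. It shows that this aromatic carbon, ortho to a large group and meta to a methyl group, is far from silent: with the rest of compound 1 held fixed, hydrogen there gives a much lower number than methyl. The data shown offer no measured basis for explaining this step.

Still open, as far as these compounds go, is whether removing this methyl has a similar effect with the shorter chains of compound 2 and compound 3. Also open, from the compounds shown here alone, are the effects of a chlorine or methoxy group on the same carbon, and of replacing the remaining methyl with hydrogen to give an unsubstituted phenyl.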